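A few compounds are considered here, and "the series" means these few. Any claim that something is new, unique, unknown or untested is made for them only; others in the source may bear on it.

Measured compounds:
compound 1, `Cn1ncc(Cl)c1-c1cc(C(=O)N[C@@H]2CN[C@H](CCN3CCC(O)CC3)C[C@H]2c2ccc(Cl)c(Cl)c2)oc1Cl`, 1140 nM in a functional assay on LNCaP cells (Homo sapiens) for antiproliferative activity; on this read-out lower numbers stand for stronger inhibition and higher numbers for weaker inhibition;
compound 2, `Cn1ncc(Cl)c1-c1cc(C(=O)N[C@@H]2CN[C@H](CCN3CCCCC3)C[C@H]2c2ccc(Cl)c(Cl)c2)oc1Cl`, 1780 nM.

Among the two measured compounds, compound 2 holds the higher number; its nearest neighbour is compound 1, and the only recorded step, a 1.6-fold higher number from compound 1 to compound 2 (0.19 log units; within the scatter), stays within the scatter.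

Compound 3, `C=CC[C@@H]1C[C@@H](c2ccc(Cl)c(Cl)c2)[C@H](NC(=O)c2cc(-c3c(Cl)cnn3C)c(Cl)o2)CN1`, has not been measured. Compared with compound 2 it carries a different group: vinyl in place of (piperidin-1-yl)methyl on a saturated chain carbon bound to a saturated ring carbon. Where compound 2 keeps one six-membered non-aromatic ring with one hetero atom and one hydrogen-bond acceptor at the end of its chain, compound 3 ends that chain in a vinyl group with no ring and no acceptor.

Among the compounds with values here, the one measured step touches only the hydroxy of the ring and offers little guidance for so large a change; no measured pair shows what removing the whole piperidin-1-yl methyl group does. Compound 3 is therefore expected to give 3500 nM, in a range of 900 nM to 14000 nM, which would mean an expected step of a 2.0-fold higher number from compound 2 to compound 3 (0.29 log units; within the scatter).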

Compound 3, half-maximal inhibitory concentration: 160 nM
Beside the measured number, compound 3's estimate is 22-fold (1.34 log units) above it, and the stated range ends above it.
By their numbers in this assay, from the lowest: compound 3; then compounds 1 and 2 (each within the scatter of the next).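

In this assay, cutting the chain back from 2-(piperidin-1-yl)ethyl to allyl gives an 11-fold lower number from compound 2 to compound 3 (1.05 log units; beyond the scatter), and the same change made on the chain with the hydroxy-bearing ring points the same way, with a 7.1-fold lower number from compound 1 to compound 3 (0.85 log units; beyond the scatter). Within the data shown here, the earlier pair showed only that the ring hydroxy could go without a change beyond the scatter, whereas this result shows that the position responds strongly to the whole group, and that the six-membered non-aromatic ring and its hydrogen-bond acceptor are not needed for the lowest number of the three. Nothing available explains this drop.

The compounds shown do not separate the double bond from the loss of the ring, since a saturated propyl chain would be needed for that. They also leave open how a shorter chain ending in a dimethylamino group or a longer alkyl chain would read out.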